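The source may report more compounds than this note shows. Statements on the series, on what has been measured and on what is new or still open speak of the compounds shown alone.

Measured in an ADME assay on HEK-293T cells (Homo sapiens) for cytotoxicity, read by CCK-8 assay, with a stated time of 48 h; a lower number here means a stronger inhibitor, a higher number a weaker inhibitor:
Compound 1 `O=C(NCCNS(=O)(=O)c1ccc(-c2ccccc2O[C@H]2CC[C@@H](O)CC2)s1)Nc1cc(C(F)(F)F)cc(C(F)(F)F)c1`: 14100 nM
Compound 2 `O=C(NCCNS(=O)(=O)c1ccc(-c2ccccc2Oc2ccc([N+](=O)[O-])c([N+](=O)[O-])c2)s1)Nc1cc(C(F)(F)F)cc(C(F)(F)F)c1`: > 50000 nM (a limit of the assay, not a number)

Compound 2 therefore has no exact place on the scale, only (the limit of > 50000 nM in this assay, at which 1 of the 2 values shown sits). Compound 3 `O=C(NCCNS(=O)(=O)c1ccc(-c2ccccc2OCc2ccccc2)s1)Nc1cc(C(F)(F)F)cc(C(F)(F)F)c1` keeps the shared core and changes one group: benzyl in place of 3,4-dinitrophenyl on an oxygen on an aromatic ring. Among the compounds with values here, one measured step bears on this change, an at least 3.5-fold higher number from compound 1 to compound 2 (0.54 log units; beyond the scatter), and it concerns the same place. That step brought in 3,4-dinitrophenyl and went with a higher number, so removing this group is expected to give a modest move to a lower number in this assay. With a single step ending at a limit, this guidance is weak. The expected step is an at least 2.0-fold lower number from compound 2 to compound 3 (0.30 log units; that floor lies within the scatter). For compound 3 the estimated value is 25000 nM, with an expected range from 9000 nM to 60000 nM.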

Compound 3, half-maximal inhibitory concentration: > 20000 nM
Compound 3: no number, only a limit; the forecaster's own chance of this, stated with the estimate: 30%; the middle value lies beyond the limit too.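

In this assay, compound 3 gives > 20000 nM, which is a limit of the assay and not a number, so this oxygen can carry benzyl, a group of carbon only, and still give no exact reading, as it does with 3,4-dinitrophenyl. Benzyl in place of 4-hydroxycyclohexyl gives an at least 1.4-fold higher number from compound 1 to compound 3 (0.15 log units; that floor lies within the scatter), so the direction fits a weaker effect on these cells than compound 1 shows, but the size of that move is not established. Going by these compounds, compound 2 and compound 3 both carry limits, so the step between them cannot be read, and whether leaving 3,4-dinitrophenyl lowers the number remains unknown.

On these data alone, the true value of compound 3 stays open, since only its limit is known. Also open, as far as these compounds go, is how this position would respond to an amine, a carboxylic acid or a longer carbon chain on the same oxygen.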